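Cyclopropyl Replaces Fluorobenzyl on the Amide Nitrogen

The compounds below may be only part of what the source reports. "The series", "measured", "known", "first", "only" and "open" are said of these compounds alone.

Among the measured compounds shown here, in a functional assay on HepG2 cells (Homo sapiens) for antiproliferative activity, read by CCK-8 assay, with a stated time of 48 h (on this read-out higher numbers stand for weaker inhibition and lower numbers for stronger inhibition), compound 2, with the structure `O=C(NCc1ccc(F)cc1)c1cc(Oc2ccc(/C=C/c3ccncc3)cc2)ccn1`, gives 37200 nM, the only number among the two compounds measured so far. Compound 1, `COc1ccc(CNC(=O)c2cc(Oc3ccc(/C=C/c4ccncc4)cc3)ccn2)cc1`, reaches only the assay limit of > 100000 nM there, a limit rather than a number (the limit of > 100000 nM in this assay, at which 1 of the 2 values shown sits). For the measured compounds named here, the one measured step, an at least 2.6-fold lower number from compound 1 to compound 2 (0.42 log units; beyond the scatter), concerns a fluoro in place of methoxy on an aromatic carbon and tells nothing about the amide side of the molecule. Compound 3, `O=C(NC1CC1)c1cc(Oc2ccc(/C=C/c3ccncc3)cc2)ccn1`, differs from compound 2 at that other place: cyclopropyl in place of 4-fluorobenzyl on an amide-type nitrogen. Going by the values given here, no measured step bears on a change of this kind, and the direction cannot be read from the data. Compound 3 is therefore expected to stay close to compound 2, with an estimated step of a 1.2-fold higher number from compound 2 to compound 3 (0.08 log units; within the scatter). The estimate for compound 3 in this assay is 45000 nM, within 12000 nM to 150000 nM.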

Compound 3, half-maximal inhibitory concentration: 77500 nM
Estimate against measurement, compound 3: 1.7-fold (0.24 log units) below, within the range that was stated.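

In this assay, the amide nitrogen proves to be a place where the substituent changes the read-out: cyclopropyl in place of 4-fluorobenzyl gives a 2.1-fold higher number from compound 2 to compound 3 (0.32 log units; beyond the scatter), so the benzyl group is not required for a measurable value, though compound 2 keeps the lower number. Cyclopropyl in place of 4-methoxybenzyl gives an at least 1.2-fold lower number from compound 1 to compound 3 (0.11 log units; that floor lies within the scatter), and that floor sets no firm order. Compound 1 stands at a limit of the assay and not at a number: the limit of > 100000 nM in this assay, at which 1 of the 3 values shown sits.

From the compounds shown here alone, it remains open how a longer alkyl chain, a basic amine such as a dimethylaminoethyl group, or a carboxylic acid would behave on this amide nitrogen. It is also unknown whether a plain benzyl or a 4-chlorobenzyl group would follow 4-fluorobenzyl.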